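This account rests on a few compounds, and the source may have more. Where it says the series, first, only, none or still open, it means among the compounds named here.

Measured so far:
- compound 1 `Clc1cccc(-n2nnnc2Cc2cccnc2)c1Cl`: 100 nM
- compound 2 `FC(F)(F)c1cccc(-n2nnnc2Cc2cccnc2)c1Cl`: 12.6 nM

In an in vitro functional assay on 1321-N1 cells for antagonist activity at P2X purinoceptor 7 (Homo sapiens), read by FLIPR and calcium flux (a lower number here means a stronger inhibitor, a higher number a weaker inhibitor), compound 2 gives the lowest number of the two measured; its nearest neighbour is compound 1, and the step of a 7.9-fold lower number from compound 1 to compound 2 (0.90 log units; beyond the scatter) was trifluoromethyl in place of chloro on an aromatic carbon. Compound 3 `Fc1ccc(-n2nnnc2Cc2cccnc2)c(Cl)c1C(F)(F)F` keeps the shared core of compound 2 and differs by fluoro in place of hydrogen on an aromatic carbon, ortho to a trifluoromethyl group, meta to a chloro group and para to a large group. For the measured compounds named here, no measured step bears directly on this kind of change: the only step in hand, a 7.9-fold lower number from compound 1 to compound 2 (0.90 log units; beyond the scatter), swaps one group for another on the same ring and says nothing about adding a fluoro. Without a precedent, the expected step of a 1.1-fold lower number from compound 2 to compound 3 (0.02 log units; within the scatter) in this assay is none beyond the scatter, either way. Compound 3 is therefore estimated at 12 nM in this assay, within the range 4 nM to 40 nM.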

Compound 3, half-maximal inhibitory concentration: 20 nM
For compound 3 the middle estimate is 1.7-fold (0.22 log units) below the measured one, within the range that was stated.
By their numbers in this assay, from the lowest: compounds 2 and 3 (each within the scatter of the next); then compound 1.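

In this assay, a 1.6-fold higher number from compound 2 to compound 3 (0.20 log units; within the scatter) shows that this aromatic carbon, ortho to a trifluoromethyl group and para to a large group, accepts fluoro in place of hydrogen without a step beyond the scatter. For the compounds shown here, the earlier step, a 7.9-fold lower number from compound 1 to compound 2 (0.90 log units; beyond the scatter), was a swap of one group for another, so this is the first reading on a carbon that carried hydrogen, and the fluoro compound 3 remains among the lowest numbers of the set. No evidence in hand accounts for this reading.

Whether an amine or a methoxy group on this same carbon would stay within the scatter of compound 2 remains open, since fluoro is the only group shown there. Also open, from the compounds shown here alone, is whether the same fluoro would read alike with chloro in place of trifluoromethyl, as in compound 1.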